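This account rests on a few compounds, and the source may have more. Where it says the series, first, only, none or still open, it means among the compounds named here.

The measured compounds:
compound 1 `O=C(Nc1cccc(C(F)(F)F)c1)c1cc(Cl)ccc1O`, with 5900 nM
compound 2 `O=C(Nc1cc(C(F)(F)F)ccc1Cl)c1cc(Cl)ccc1O`, with 3500 nM
compound 3 `O=C(Nc1cc(Cl)cc(Cl)c1)c1cc(Cl)ccc1O`, with 3100 nM

All three values come from an ADME assay on cells (Macrophage, Mus musculus) for cytotoxicity, read by resazurin assay, with a stated time of 3 days; on this read-out lower numbers stand for stronger inhibition and higher numbers for weaker inhibition. Compound 1 and compound 2 differ in a single place, (chloro in place of hydrogen on an aromatic carbon), and that change gave a 1.7-fold lower number from compound 1 to compound 2 (0.23 log units; within the scatter). Compound 3 shares a core with compound 1, but the difference between the two cores is not broken down here. Compound 4 `O=C(Nc1cc(Cl)c(Cl)c(Cl)c1)c1cc(Cl)ccc1O` has not yet been measured in this assay; it differs from compound 3 by chloro in place of hydrogen on an aromatic carbon. Among the compounds with values here, this is the same kind of change as the one from compound 1 to compound 2, though the surroundings differ: in compound 2 the entering chloro sits ortho to a large group and para to a trifluoromethyl group, whereas in compound 4 it sits ortho to two chloro groups and para to a large group. Within the data shown here, for compound 4 a step of about a 1.2-fold lower number from compound 3 to compound 4 (0.09 log units; within the scatter) is expected because a 1.7-fold lower number from compound 1 to compound 2 (0.23 log units; within the scatter) was the only measured example of this kind of change and stayed small. Compound 4 is therefore estimated at 2500 nM, expected to fall between 1200 nM and 5000 nM.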

Compound 4, half-maximal inhibitory concentration: 5400 nM
The estimate for compound 4 lay 2.2-fold (0.33 log units) below the measured number; the measured number lies above the stated range.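

In this assay, putting a chloro in place of a hydrogen on the aromatic carbon gave a 1.7-fold higher number from compound 3 to compound 4 (0.24 log units; within the scatter), a step that on its own is no larger than repeated measurements can produce. Set beside the earlier case, however, the same change did not carry over unchanged from one core to the other: the same change on two cores in this assay, a 1.7-fold lower number (0.23 log units; within the scatter) from compound 1 to compound 2 and a 1.7-fold higher number (0.24 log units; within the scatter) from compound 3 to compound 4, 2.9-fold (0.47 log units) apart, beyond the scatter of two such steps This shows that, in this series, a step measured on one core was not a safe guide to the same change on another, even for a single added chloro, but it rests on only two pairs of compounds and does not show why the two steps part.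

The compounds shown leave open whether a third core would follow either of these two steps or behave differently again. They also leave open how an amine, a carboxylic acid or a longer chain on that same aromatic carbon would read in this assay.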